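The source may report more compounds than this note shows. Statements on the series, on what has been measured and on what is new or still open speak of the compounds shown alone.

Compound 1 `CC(C)CN1C(=O)c2ccccc2[C@H](C(=O)Nc2ccc(F)c(C#N)c2)[C@H]1c1ccoc1` is the starting point of this account. In a physicochemical assay for solubility, in phosphate buffer, with a stated time of 18 h, at pH 7 (on this read-out lower numbers stand for lower solubility and higher numbers for higher solubility), compound 1 gives 15000 nM, the lowest of the two numbers recorded so far. Among the compounds with values here, its only measured neighbour is compound 2 `CC(C)CN1C(=O)c2ccccc2[C@H](C(=O)Nc2ccc(F)c(C#N)c2)[C@H]1c1cncnc1`, which in this assay gives 54000 nM; the single measured step, a 3.6-fold higher number from compound 1 to compound 2 (0.56 log units; beyond the scatter), is a modest rise that lies beyond the scatter.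

Compound 3 `CC(C)CN1C(=O)c2ccccc2[C@H](C(=O)Nc2ccc(F)c(C#N)c2)[C@H]1c1ccno1` has not yet been measured. It differs from compound 1 in one place: 1,2-oxazol-5-yl in place of furan-3-yl on a saturated ring carbon. Within the data shown here, the one step that bears on this change is the step from compound 1 to compound 2, where a different five-membered aromatic ring bearing two hetero atoms replaced the same furan-3-yl and the number rose by a 3.6-fold higher number from compound 1 to compound 2 (0.56 log units; beyond the scatter). A rise in the same direction is therefore expected for compound 3, though nothing measured shows whether it reaches the same size, so the expectation for this assay is a step that is modest and possibly within the scatter. The expected step is a 2.0-fold higher number from compound 1 to compound 3 (0.30 log units; within the scatter). Compound 3 is accordingly estimated at 30000 nM, with a range from 12000 nM to 75000 nM.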

Compound 3, solubility: 53000 nM
For compound 3 the middle estimate is 1.8-fold (0.25 log units) below the measured one, within the range that was stated.
By their numbers in this assay, from the lowest: compound 1; then compounds 3 and 2 (each within the scatter of the next).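

In this assay, placing 1,2-oxazol-5-yl on this saturated ring carbon, next to the ring nitrogen, gives a 3.5-fold higher number from compound 1 to compound 3 (0.55 log units; beyond the scatter), so a second replacement of furan-3-yl at this position moves the number in the same direction as pyrimidin-5-yl. The two replacements cannot be told apart on this read-out, with a 1.0-fold lower number from compound 2 to compound 3 (0.01 log units; within the scatter), which leaves compound 1, with furan-3-yl, as the lowest of the three while compounds 2 and 3 stand level within the scatter. Nothing available explains why these replacements raise the number or why the two arrive at such similar values.

The compounds shown leave open whether the level reached by compounds 2 and 3 holds for other rings at this position, such as 1,2-oxazol-3-yl, a plain phenyl or a pyridine, and so whether the rise follows the ring nitrogen at all. They also leave open what a group carrying an amine or a carboxylic acid would give on this carbon, where only aromatic rings appear so far.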